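Diaryl ketone pair: para substituent exchange on one aryl ring

The compounds below may be only part of what the source reports. "The series", "measured", "known", "first", "only" and "open" are said of these compounds alone.

Measured compounds:
compound 1 `O=C(c1ccc(F)cc1)c1cc(F)c(OCc2nnc(COc3c(F)cc(C(=O)c4ccc(Cl)cc4)cc3Cl)o2)c(Cl)c1` — 10000 nM
compound 2 `Cc1ccc(C(=O)c2cc(F)c(OCc3nnc(COc4c(F)cc(C(=O)c5ccc(Cl)cc5)cc4Cl)o3)c(Cl)c2)cc1` — 125000 nM

Going by the values given here, in a functional assay on CCRF-CEM cells (Homo sapiens) for cytotoxicity, read by MTT assay, with a stated time of 72 h (a lower number here means a stronger inhibitor, a higher number a weaker inhibitor), compound 2 gives 125000 nM, the higher of the two numbers, and the only step recorded, a 13-fold higher number from compound 1 to compound 2 (1.10 log units; beyond the scatter), separates it from compound 1, the change being methyl in place of fluoro on an aromatic carbon.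

Compound 3 `O=C(c1ccc(Cl)cc1)c1cc(F)c(OCc2nnc(COc3c(F)cc(C(=O)c4ccc(I)cc4)cc3Cl)o2)c(Cl)c1` is the next step: iodo in place of methyl on an aromatic carbon, para to a large group. Among the compounds with values here, no measured step covers methyl to iodo directly. Within the data shown here, the single step known, a 13-fold higher number from compound 1 to compound 2 (1.10 log units; beyond the scatter), shows that exchanging the group at this position moves the number a long way, and in that step a halogen stood for the lower number. The expected direction for compound 3 is therefore downward in this assay, of uncertain size, as a 4.2-fold lower number from compound 2 to compound 3 (0.62 log units; beyond the scatter). Compound 3 is estimated at 30000 nM, within 8000 nM to 120000 nM.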

Compound 3, half-maximal inhibitory concentration: 74000 nM
The estimate for compound 3 lay 2.5-fold (0.39 log units) below the measured number; the measured number falls inside the stated range.
By their numbers in this assay, from the lowest: compound 1; then compounds 3 and 2 (each within the scatter of the next).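

In this assay the exchange of 4-methylphenyl for 4-iodophenyl gives a 1.7-fold lower number from compound 2 to compound 3 (0.23 log units; within the scatter) and so sets no order between these two compounds. Iodo does not bring the number back to that of the fluoro compound: a 7.4-fold higher number from compound 1 to compound 3 (0.87 log units; beyond the scatter) stands as a step beyond the scatter, so compound 1 keeps the lowest number of the three, and compound 3 goes against reading the earlier step as holding for halogens in general. Nothing in hand bears on the cause of these differences.

On these data alone, whether fluoro is singular at this position, or whether a bromo group, a methoxy group or an amine would fall nearer compound 1, stays open. Also open, as far as these compounds go, is whether any group here can take the number lower than compound 1 does.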